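This account rests on a few compounds, and the source may have more. Where it says the series, first, only, none or still open, it means among the compounds named here.

Three compounds here share one core and differ only in the group carried on one of its aromatic carbons. Compound 1 `COc1cccc(Oc2ccc3cc(NC(=O)c4ccc(OC(C)=O)c(CC=C(C)C)c4)c(=O)oc3c2C)c1` gives 15700 nM in a functional assay on MCF7 cells (Homo sapiens) for antiproliferative activity; a lower number here means a stronger inhibitor, a higher number a weaker inhibitor. Compound 2 `COc1ccc(Nc2ccc3cc(NC(=O)c4ccc(OC(C)=O)c(CC=C(C)C)c4)c(=O)oc3c2C)cc1` reaches only the limit of > 100000 nM in this assay, so it supplies a limit rather than a number. Compound 3 `COc1ccc(Cc2ccc3cc(NC(=O)c4ccc(OC(C)=O)c(CC=C(C)C)c4)c(=O)oc3c2C)cc1` gives 11500 nM in this assay; among the two numbers it is the lower one, with compound 1 as its nearest neighbour, the two lying close together (a 1.4-fold lower number from compound 1 to compound 3 (0.14 log units; within the scatter)). The step from compound 2 is larger (an at least 8.6-fold lower number from compound 2 to compound 3 (0.93 log units; beyond the scatter)), but it rests on the limit of > 100000 nM in this assay, at which 1 of the 3 values shown sits, and cannot be sized exactly.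

Compound 4 `COCOc1ccc(Cc2ccc3cc(NC(=O)c4ccc(OC(C)=O)c(CC=C(C)C)c4)c(=O)oc3c2C)cc1OC` has not been measured. It differs from compound 3 by 3-methoxy-4-(methoxymethoxy)phenyl in place of 4-methoxyphenyl on a saturated chain carbon bound to an aromatic carbon. Among the compounds with values here, the measured steps all concern the link between the core and the aromatic group, not the substituents on that ring, so no measured step bears directly on this change. Within the data shown here, the one step that compares two full numbers (a 1.4-fold lower number from compound 1 to compound 3 (0.14 log units; within the scatter)) stayed within the scatter. In this assay the expected change is therefore small, a 1.2-fold lower number from compound 3 to compound 4 (0.06 log units; within the scatter). Compound 4 is expected to give about 10000 nM. For compound 4 the estimated range runs from 4000 nM to 30000 nM.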

Compound 4, half-maximal inhibitory concentration: 14900 nM
Compound 4: middle estimate off by 1.5-fold (0.17 log units), on the low side; low and high end bracket the measured number.
By their numbers in this assay, from the lowest: compounds 3, 4 and 1 (each within the scatter of the next). At a limit, above all of these: compound 2.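

Within the data shown here, until now the measured steps at this position had changed only the link between the core and the aromatic group, so the step to compound 4 is the first to change the substituents on the ring itself, and in this assay it comes to a 1.3-fold higher number from compound 3 to compound 4 (0.11 log units; within the scatter) for this change. Replacing 4-methoxyphenyl with 3-methoxy-4-(methoxymethoxy)phenyl on a saturated chain carbon bound to an aromatic carbon raises the count of heavy atoms and hydrogen-bond acceptors, yet the number stays within the scatter, so this larger group is tolerated here in this assay. Nothing in the data shown accounts for this lack of change.

The compounds shown leave open whether a free hydroxyl in place of the methoxymethoxy group, or an amine or a carboxylic acid on this ring, would move the number beyond the scatter. They also leave open whether the same ring substituents would behave alike with the ether link of compound 1 in place of the saturated chain carbon.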